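Cytotoxicity on the shared core: aryl amide variation

A few compounds are considered here, and "the series" means these few. Any claim that something is new, unique, unknown or untested is made for them only; others in the source may bear on it.

Measured compounds:
compound 1, `Cc1cc(S(N)(=O)=O)ccc1NC(=O)COc1ccc(Cl)cc1NC(=O)c1ccccc1[N+](=O)[O-]`, 54800 nM
compound 2, `Cc1cc(S(N)(=O)=O)ccc1NC(=O)COc1ccc(Cl)cc1NC(=O)c1cc(Cl)cc(Br)c1`, 114000 nM
compound 3, `Cc1cc(S(N)(=O)=O)ccc1NC(=O)COc1ccc(Cl)cc1NC(=O)c1cc(Br)cc(Br)c1`, 89700 nM

In a functional assay on C8166 cells (Homo sapiens) for cytotoxicity, read by MTT assay (a higher number here means that more compound is tolerated, a lower number that less compound is tolerated), compound 1 gives the lowest number of the three; its nearest neighbour is compound 3, with a 1.6-fold higher number from compound 1 to compound 3 (0.21 log units; within the scatter), and the widest gap is a 2.1-fold higher number from compound 1 to compound 2 (0.32 log units; beyond the scatter). Between compounds 2 and 3 the step is a 1.3-fold lower number from compound 2 to compound 3 (0.10 log units; within the scatter).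

The unmeasured compound 4, `Cc1cc(S(N)(=O)=O)ccc1NC(=O)COc1ccc(Cl)cc1NC(=O)c1cccc2ccccc12`, differs from compound 1 at the aryl group on the carbonyl carbon: naphthalen-1-yl in place of 2-nitrophenyl on a carbonyl carbon.

Within the data shown here, two measured steps bear on this change, both replacing the 2-nitrophenyl group on the same carbonyl carbon: a 2.1-fold higher number from compound 1 to compound 2 (0.32 log units; beyond the scatter) and a 1.6-fold higher number from compound 1 to compound 3 (0.21 log units; within the scatter). Both point towards a higher number, one beyond the scatter and one within it, so the step from compound 1 to compound 4 is expected to be modest and towards a higher number, or none beyond the scatter. Among the measured compounds shown here, no measured step involves a naphthalen-1-yl group, so the estimate is loose.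

Compound 4 is therefore expected to give about 80000 nM in this assay, within 40000 nM to 160000 nM, which means an expected step of a 1.5-fold higher number from compound 1 to compound 4 (0.16 log units; within the scatter).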

Compound 4, half-maximal cytotoxic concentration: > 381000 nM
Compound 4 ended at the assay's limit; the forecaster's own chance of this, stated with the estimate: 20%; middle value at least 4.7-fold (0.67 log units) from the limit.
By their numbers in this assay, from the lowest: compounds 1, 3 and 2 (each within the scatter of the next, the first and the last beyond it). At a limit, above all of these: compound 4.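

In this assay, compound 4 stands at a limit and not at a number: the limit of > 381000 nM in this assay, at which 1 of the 4 values shown sits.

Read against that limit, naphthalen-1-yl on the carbonyl carbon stands apart from all three substituted phenyl groups, each step beyond the scatter: an at least 6.9-fold higher number from compound 1 to compound 4 (0.84 log units; beyond the scatter), an at least 4.2-fold higher number from compound 3 to compound 4 (0.62 log units; beyond the scatter) and an at least 3.3-fold higher number from compound 2 to compound 4 (0.52 log units; beyond the scatter). The widest step among the phenyl groups was a 2.1-fold higher number from compound 1 to compound 2 (0.32 log units; beyond the scatter), so this position allows a wider range in this assay than compounds 1, 2 and 3 showed.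

As far as these compounds go, the full size of the three new steps stays open, as they rest on a limit. What an unsubstituted phenyl or a cyclohexyl group on the same carbonyl carbon would give also stays open, so the compounds shown cannot tell whether the second aromatic ring of naphthalen-1-yl is what matters.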